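The compounds below may be only part of what the source reports. "The series", "measured", "known", "first", "only" and "open" are said of these compounds alone.

Compound 1 `Nc1nc(Cl)c2ncn(Cc3ccccc3CCl)c2n1` and compound 2 `ClCc1cccc(Cn2cnc3nc(Cl)nc(Cl)c32)c1` share a fused two-ring core carrying a benzyl substituent, and both were tested in a functional assay on SF-295 cells (Homo sapiens) for cytotoxicity, read by sulforhodamine B assay, with a stated time of 48 h; on this read-out higher numbers stand for lower toxicity in this test and lower numbers for higher toxicity in this test. In this assay compound 1 gives 63100 nM, the highest number among the two compounds measured. Compound 2 gives 6300 nM, a lower number, and the gap between the two values lies beyond the usual scatter of repeated measurements. Going by the values given here, compound 1 and compound 2 differ in more than one place, so these two values show only that compound 2 is the more toxic of the pair here, not which change is responsible.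

Compound 3 `ClCc1ccccc1Cn1cnc2c(Cl)ncnc21` has not yet been measured in this assay. It differs from compound 1 in one place: hydrogen in place of amino on an aromatic carbon. Among the compounds with values here, no pair of measured compounds shows the effect of this change on its own, so the direction of any step is open. The expected step from compound 1 to compound 3 is a 1.6-fold lower number from compound 1 to compound 3 (0.20 log units; within the scatter), small and not clearly beyond the scatter. Compound 3 is therefore estimated to give about 40000 nM in this assay, with a likely range from 10000 nM to 160000 nM.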

Compound 3, concentration lethal to 50% of the cells: 51300 nM
The estimate for compound 3 lay 1.3-fold (0.11 log units) below the measured number, within the range that was stated.
By their numbers in this assay, from the lowest: compound 2; then compounds 3 and 1 (each within the scatter of the next).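

In this assay, going by these compounds alone, hydrogen in place of amino on the aromatic carbon between two ring nitrogen atoms gives a 1.2-fold lower number from compound 1 to compound 3 (0.09 log units; within the scatter), and this pair is the first to show this change on its own. Within the data shown here, compound 1 and compound 2 differ in more than one place and could not isolate it, whereas here only this one group changes and the step stays within the scatter, so in this pair the amino group makes no difference that can be told apart from repeat-to-repeat variation in this test. No available measurement explains this result.

As far as these compounds go, whether another group on this carbon, such as methoxy or dimethylamino, would give a step beyond the scatter stays open, as only amino and hydrogen can be read here on their own. From the compounds shown here alone, compound 2 differs from compound 1 in more than one place, so it also remains open which of those differences goes with the lower number of compound 2 in this assay.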